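From carbamoyl to (trifluoromethyl)sulfanyl on compound 2

The compounds below may be only part of what the source reports. "The series", "measured", "known", "first", "only" and "open" are said of these compounds alone.

Measured so far in a physicochemical assay for solubility, using the shake flask method, in simulated intestinal fluid, measured as kinetic solubility, with a stated time of 2 h, at 25 degrees C, at pH 6.5; a higher number here means a more soluble compound, a lower number a less soluble compound:
- Compound 1 `Cc1noc(-c2nc(C)c3c(c2N)C(=O)N(Cc2ccc(S(C)(=O)=O)cc2)C3=O)n1`: < 5000 nM (a limit)
- Compound 2 `Cc1noc(-c2nc(C)c3c(c2N)C(=O)N(Cc2ccc(C(N)=O)cc2)C3=O)n1`: < 5000 nM (a limit)

Compound 2 gives < 5000 nM, which is a limit and not a number. Compound 1 shares that position: the limit of < 5000 nM in this assay, at which 2 of the 2 values shown sit. Compound 3 `Cc1noc(-c2nc(C)c3c(c2N)C(=O)N(Cc2ccc(SC(F)(F)F)cc2)C3=O)n1` carries (trifluoromethyl)sulfanyl in place of carbamoyl on an aromatic carbon, para to a large group: (trifluoromethyl)sulfanyl in place of carbamoyl on an aromatic carbon. Among the compounds with values here, the only measured step that bears on this change is a step that the two limits leave unreadable from compound 1 to compound 2, so it offers no size to carry over. No step beyond the scatter is therefore expected in this assay, and the estimated step is a step that the limit leaves unreadable from compound 2 to compound 3. For compound 3 the estimate is 2500 nM, with an expected range of 500 nM to 5000 nM.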

Compound 3, solubility: < 5000 nM
Compound 3 gave a limit, no number; the forecaster's own chance of this, stated with the estimate: 85%; the middle value is on the limit's open side.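

No step can be read among compound 1, compound 2 and compound 3, as each gives only a limit and not a number. Going by these compounds, whether these three compounds differ in solubility at all, and by how much, stays open.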